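From 4-bromophenyl to 3-fluorophenyl on an amine nitrogen

A few compounds are considered here, and "the series" means these few. Any claim that something is new, unique, unknown or untested is made for them only; others in the source may bear on it.

In a functional assay on KB cells (Homo sapiens) for cytotoxicity, read by sulforhodamine B assay (on this read-out higher numbers stand for weaker inhibition and lower numbers for stronger inhibition), compound 2 `C=C1[C@@H](OC(C)=O)C[C@@H]2[C@](C)(CO[Si](C)(C)C(C)(C)C)[C@H](OC(C)=O)CC[C@@]2(C)[C@@H]1C[C@@H](Nc1ccc(Br)cc1)C1=CCOC1=O` gives 5230 nM. Compound 1 `C=C1[C@@H](OC(C)=O)C[C@@H]2[C@](C)(CO[Si](C)(C)C(C)(C)C)[C@H](OC(C)=O)CC[C@@]2(C)[C@@H]1C[C@@H](Nc1ccc(OC)c(OC)c1)C1=CCOC1=O` gives 5800 nM and compound 3 `C=C1CC[C@@H]2[C@](C)(CO[Si](C)(C)C(C)(C)C)[C@H](OC(C)=O)CC[C@@]2(C)[C@@H]1C/C=C1/C(=O)OC[C@H]1OC(C)=O` gives 5050 nM, so compound 2 sits level with both, within the usual scatter of repeated measurements.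

Compound 4 `C=C1[C@@H](OC(C)=O)C[C@@H]2[C@](C)(CO[Si](C)(C)C(C)(C)C)[C@H](OC(C)=O)CC[C@@]2(C)[C@@H]1C[C@@H](Nc1cccc(F)c1)C1=CCOC1=O` differs from compound 2 in one place, with 3-fluorophenyl in place of 4-bromophenyl on an amine nitrogen.

For the measured compounds named here, only one measured step touches the group on that nitrogen: a 1.1-fold lower number from compound 1 to compound 2 (0.04 log units; within the scatter), with 4-bromophenyl in place of 3,4-dimethoxyphenyl. That step stayed within the scatter. Going by the values given here, it is a single example, however, and no compound carrying 3-fluorophenyl has a measured value yet. No shift beyond the scatter is therefore expected in this assay, in either direction, and the estimated step is a 1.0-fold lower number from compound 2 to compound 4 (0.00 log units; within the scatter).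

For compound 4 the expected value is 5200 nM, with an estimated range of 2800 nM to 9500 nM.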

Compound 4, half-maximal inhibitory concentration: 4560 nM
Estimate against measurement, compound 4: 1.1-fold (0.06 log units) above; low and high end bracket the measured number.
By their numbers in this assay, from the lowest: compounds 4, 3, 2 and 1 (each within the scatter of the next).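

Adding compound 4 gives a third aryl group on the amine nitrogen, and in this assay the number barely moves: a 1.1-fold lower number from compound 2 to compound 4 (0.06 log units; within the scatter), and a 1.3-fold lower number from compound 1 to compound 4 (0.10 log units; within the scatter). For the compounds shown here, both steps lie within the scatter, so 3,4-dimethoxyphenyl, 4-bromophenyl and 3-fluorophenyl all read alike here, which turns the single earlier comparison into a small series of three compounds with no measurable difference between them. No available evidence bears on why these three compounds read alike.

From the compounds shown here alone, all three compounds carry a substituted phenyl ring on this nitrogen, so it remains open whether a group of another kind, such as a plain alkyl chain or a phenyl ring bearing a carboxylic acid, would shift the number. Going by these compounds, it is equally open whether any group here could take the number beyond the scatter.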